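The compounds below may be only part of what the source reports. "The series", "measured", "known", "first", "only" and "open" are said of these compounds alone.

Measured in a functional assay on MCF7 cells (Homo sapiens) for inhibition, with a stated time of 72 h; a higher number here means a weaker inhibitor, a lower number a stronger inhibitor:
Compound 1 `NC1CCC(Nc2nc(NCc3ccc(-c4ccco4)cc3)c3ncn(C4CCCC4)c3n2)CC1`: 85 nM
Compound 2 `CC(C)(O)CNc1nc(NCc2ccc(-c3ccco3)cc2)c2ncn(C3CCCC3)c2n1`: 15300 nM

Of these two compounds, compound 2 has the higher number, 15300 nM, which makes it the weaker inhibitor of the pair. For the measured compounds named here, the only measured step separates the two: a 180-fold higher number from compound 1 to compound 2 (2.26 log units; beyond the scatter). Compound 3 `CC(C)(O)CNc1nc(NCc2ccc(-c3ccco3)nc2)c2ncn(C3CCCC3)c2n1` keeps the rest of compound 2 and differs in one group: 6-(furan-2-yl)pyridin-3-yl in place of 4-(furan-2-yl)phenyl on a saturated chain carbon bound to a nitrogen on an aromatic ring. The measured step changed a different group, on a nitrogen on an aromatic ring, so it does not show what this new exchange will do. Going by the values given here, it shows only that a single change can move the number a long way. Among the compounds with values here, no measured compound carries the 6-(furan-2-yl)pyridin-3-yl group, so the data give no direction for the exchange. In this assay, no step beyond the scatter is therefore expected, although the uncertainty is wide. The expected step is a 1.0-fold lower number from compound 2 to compound 3 (0.01 log units; within the scatter). Compound 3 is estimated at 15000 nM, with an expected range from 5000 nM to 45000 nM.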

Compound 3, half-maximal inhibitory concentration: 1310 nM
The estimate for compound 3 lay 11-fold (1.06 log units) above the measured number, outside the stated range (below it).
By their numbers in this assay, from the lowest: compound 1; then compound 3; then compound 2.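

In this assay, the exchange of 4-(furan-2-yl)phenyl for 6-(furan-2-yl)pyridin-3-yl gives a 12-fold lower number from compound 2 to compound 3 (1.07 log units; beyond the scatter) and so shows that this place, on a saturated chain carbon bound to a nitrogen on an aromatic ring, also responds strongly to a single change. The two groups have the same count of heavy atoms and differ in the six-membered aromatic ring, where the entering group holds a nitrogen in place of one carbon and has one more hydrogen-bond acceptor, so a small change in composition is enough for a large step in this series. No measurement shown here accounts for the direction or size of this step.

The compounds shown leave open whether the same exchange would also lower the number in compound 1, which keeps the 4-aminocyclohexyl group, and whether the two changes would add up in one molecule. They also leave open what a pyrimidine ring in place of the pyridine, or a thiophene in place of the furan, would do at this place.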